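The source may hold more compounds than are shown below. What is called first, only, known or untested is meant among the compounds shown, and "the series" means these compounds.

Measured in an assay on isolated protein for inhibition of Calpain-1 catalytic subunit (Homo sapiens); on this read-out lower numbers stand for stronger inhibition and higher numbers for weaker inhibition:
compound 1 `CCC(NC(=O)C(CC(C)C)NC(=O)OCc1ccccc1)C(=O)C(=O)NCC1CCCCC1` gives 680 nM;
compound 2 `CCC(NC(=O)C(CC(C)C)NC(=O)OCc1ccccc1)C(=O)C(=O)NCc1nccc2ccccc12` gives 250 nM;
compound 3 `CCC(NC(=O)C(CC(C)C)NC(=O)OCc1ccccc1)C(=O)C(=O)NCCCN1CCCc2ccccc21` gives 370 nM.

Compound 1 has the highest number of the three. Compound 4 `CCC(NC(=O)C(CC(C)C)NC(=O)OCc1ccccc1)C(=O)C(=O)NCCCN1CCc2ccccc2C1` differs from it by 2-(1,2,3,4-tetrahydroisoquinolin-2-yl)ethyl in place of cyclohexyl on a saturated chain carbon bound to an amide-type nitrogen. For the measured compounds named here, two measured steps bear on this change. The step of a 1.8-fold lower number from compound 1 to compound 3 (0.26 log units; within the scatter) uses the closest analogue, a tetrahydroquinolinyl-ethyl group on the same carbon. The step of a 2.7-fold lower number from compound 1 to compound 2 (0.43 log units; beyond the scatter) gives a larger lowering with an aromatic bicycle. For compound 4 a lowering of the order seen for compound 3 is expected in this assay, that is a 1.9-fold lower number from compound 1 to compound 4 (0.29 log units; within the scatter), at the edge of the scatter. Compound 4 is therefore estimated at 350 nM, within 150 nM to 800 nM.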

Compound 4, inhibition constant: 310 nM
Estimate against measurement, compound 4: 1.1-fold (0.05 log units) above; the measured number falls inside the stated range.
By their numbers in this assay, from the lowest: compounds 2, 4, 3 and 1 (each within the scatter of the next, the first and the last beyond it).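

In this assay, the 2-(1,2,3,4-tetrahydroisoquinolin-2-yl)ethyl group gives a 2.2-fold lower number from compound 1 to compound 4 (0.34 log units; beyond the scatter), so a replacement of cyclohexyl carrying a non-aromatic nitrogen ring now passes the scatter, which until now only isoquinolin-1-yl had done. The ring isomers cannot be told apart, with a 1.2-fold lower number from compound 3 to compound 4 (0.08 log units; within the scatter), and the new group also stays within the scatter of isoquinolin-1-yl, with a 1.2-fold higher number from compound 2 to compound 4 (0.09 log units; within the scatter). No available evidence accounts for these numbers.

As far as these compounds go, how a carboxylic acid or an open-chain amine would compare at this place remains open. So does the effect of a longer chain in place of the ethyl.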